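Chloro in place of nitro: expectation for compound 4

This account rests on a few compounds, and the source may have more. Where it says the series, first, only, none or still open, it means among the compounds named here.

Values in a toxicity assay on THP-1 cells (Homo sapiens) for inhibition (a lower number here means that less compound is tolerated, a higher number that more compound is tolerated), follow.
compound 1 `Cc1ccccc1-c1cnc(NC(=O)c2ccc(F)cc2)n1C` gives > 50000 nM as a limit
compound 2 `Cn1c(-c2ccc(Cl)cc2)cnc1NC(=O)c1ccc(F)cc1` gives 37000 nM as a number
compound 3 `Cn1c(-c2cccc([N+](=O)[O-])c2)cnc1NC(=O)c1ccc(F)cc1` gives > 50000 nM as a limit

Compound 3 stands only at a limit, with > 50000 nM as its reading. Among the measured compounds shown here, compound 4 `Cn1c(-c2cccc(Cl)c2)cnc1NC(=O)c1ccc(F)cc1` carries chloro in place of nitro on an aromatic carbon as its one change, chloro in place of nitro on an aromatic carbon. For the measured compounds named here, the only measured step is an at least 1.3-fold lower number from compound 1 to compound 2 (0.13 log units; that floor lies within the scatter) and it concerns a different change, so it bears only loosely. Going by the values given here, compound 2 gives 37000 nM as the one chloro compound with a number. A small step to a lower number, or none beyond the scatter, is therefore expected in this assay and is estimated as an at least 1.2-fold lower number from compound 3 to compound 4 (0.09 log units; that floor lies within the scatter) for now. Compound 4 is estimated at 40000 nM with 20000 nM to 70000 nM as the expected range.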

Compound 4, half-maximal cytotoxic concentration: > 50000 nM
Compound 4 ended at the assay's limit; the forecaster's own chance of this, stated with the estimate: 40%; at least 1.2-fold (0.09 log units) between middle value and limit.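

In this assay, 3-chlorophenyl in place of 4-chlorophenyl gives an at least 1.3-fold higher number from compound 2 to compound 4 (0.13 log units; that floor lies within the scatter). Compound 4 gives only a limit, > 50000 nM, so chloro on this aromatic carbon, meta to a large group, yields no number. The steps to compound 4 from compound 3 and from compound 1 cannot be read, because both ends of each are limits: the limit of > 50000 nM in this assay, at which 3 of the 4 values shown sit.

Going by these compounds, how far compound 1, compound 3 and compound 4 lie from one another stays open. Also open, on these data alone, is whether an amine or a carboxylic acid on this aromatic carbon would give a number in this assay.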